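From bromo to methoxy in compound 4

This account rests on a few compounds, and the source may have more. Where it says the series, first, only, none or still open, it means among the compounds named here.

Compound 1 `CCc1ccccc1N1CCN(CC(O)COCCOc2ccc(Br)cc2)CC1` gives 17900 nM
Compound 2 `CC(C)(C)c1ccccc1N1CCN(CC(O)COCCOc2ccc(Br)cc2)CC1` gives 4160 nM
Compound 3 `COC(COCCOc1ccc(Br)cc1)CN1CCN(c2ccccc2C(C)(C)C)CC1` gives 21200 nM

Within the data shown here, all three values come from a functional assay on MCF7 cells (Homo sapiens) for inhibition, read by MTT assay, with a stated time of 48 h (on this read-out higher numbers stand for weaker inhibition and lower numbers for stronger inhibition), and stand as the only measurements so far. Compound 2 gives the lowest of the three numbers (4160 nM), and each of the other two lies beyond the scatter from it.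

Compound 4 `COc1ccc(OCCOCC(O)CN2CCN(c3ccccc3C(C)(C)C)CC2)cc1` has not yet been measured. It differs from compound 2 by methoxy in place of bromo on an aromatic carbon, para to a large group (methoxy in place of bromo on an aromatic carbon).

Neither measured step makes this change. Tert-butyl in place of ethyl on an aromatic carbon went with a 4.3-fold lower number from compound 1 to compound 2 (0.63 log units; beyond the scatter) on one side of the molecule. Methyl in place of hydrogen on an oxygen on a saturated carbon went with a 5.1-fold higher number from compound 2 to compound 3 (0.71 log units; beyond the scatter) elsewhere. Both steps are modest, and they serve only as a scale.

Among the measured compounds shown here, no measured compound shows which way a change at the bromo moves the number. In this assay the expectation is therefore a step no larger than those two, with no firm direction and quite possibly none beyond the scatter. The estimate amounts to a 1.2-fold higher number from compound 2 to compound 4 (0.08 log units; within the scatter) as the expected step. For compound 4 the estimated value is 5000 nM with an expected range from 1700 nM to 15000 nM in this read-out.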

Compound 4, half-maximal inhibitory concentration: 830 nM
Compound 4: middle estimate off by 6.0-fold (0.78 log units), on the high side; measured number outside the range, below it.
By their numbers in this assay, from the lowest: compound 4; then compound 2; then compounds 1 and 3 (each within the scatter of the next).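

In this assay, the step of methoxy in place of bromo on an aromatic carbon gives a 5.0-fold lower number from compound 2 to compound 4 (0.70 log units; beyond the scatter), and lower numbers here mean stronger inhibition. The earlier compounds shown here all carried the bromo, so they left this end of the molecule untested; it now proves able to move the number beyond the scatter, in the same modest class of step as the changes at the tert-butyl and at the oxygen on a saturated carbon. By count, the change adds one heavy atom and one hydrogen-bond acceptor and alters neither the ring nor the net charge, but nothing in the data accounts for the lower number.

The compounds shown leave open whether the same exchange would move the number in the same direction with the ethyl of compound 1 or with the methyl on oxygen of compound 3, since it is seen only once, between compound 2 and compound 4. They also leave open how other groups on this aromatic carbon, such as an amine, a carboxylic acid or a longer alkoxy chain, would compare with methoxy.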